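The source may hold more compounds than are shown below. What is called first, only, known or untested is meant among the compounds shown, and "the series" means these compounds.

Notes on the series in a functional assay on A549 cells (Homo sapiens) for cytotoxicity, read by MTT assay, with a stated time of 4 days; a higher number here means a weaker inhibitor, a lower number a stronger inhibitor.

Compound 1 `C=C1C[C@]23C[C@@]1(O)CC[C@H]2c1ccc(OS(=O)(=O)c2ccc(C)cc2)c(C)c1[C@@H]3Cn1cc(-c2ccc(Br)cc2)nn1` returns in this assay only > 20000 nM, which is a limit of the assay and not a number. Compound 2 `C=C1C[C@]23C[C@@]1(O)CC[C@@H]2c1cccc(C)c1[C@@H]3Cn1cc(-c2ccc(C)cc2)nn1` likewise returns > 20000 nM, again a limit rather than a measured value. Among the compounds with values here, compound 3 `C=C1C(=O)[C@]23C[C@@]1(O)CC[C@H]2c1ccc(O)c(C)c1[C@@H]3Cn1cc(-c2ccc(C(F)(F)F)cc2)nn1` is the single member with a number here, at 1110 nM. Where compound 1 stands is therefore given by the limit of > 20000 nM in this assay, at which 2 of the 3 values shown sit, and nothing finer can be said of its position than that it sits at that limit. Within the data shown here, no pair of measured compounds in this set differs in one place only, so no measured step is available to calibrate the size of any single change.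

Compound 4 `C=C1C[C@]23C[C@@]1(O)CC[C@H]2c1ccc(OS(=O)(=O)c2ccc(C)cc2)c(C)c1[C@@H]3Cn1cc(-c2ccccn2)nn1` has not yet been measured in this assay. It differs from compound 1 in a single place: pyridin-2-yl in place of 4-bromophenyl on an aromatic carbon. The remainder of the structure, including the shared core of compound 1, is unchanged.

Since compound 1 stands at the limit, the expected size of the step is a number no higher from compound 1 to compound 4 (the limit leaves the size open), no shift beyond the scatter in either direction. Compound 4 is therefore expected to give 20000 nM, in a range from 5000 nM to 60000 nM, most likely reported again only as a limit.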

Compound 4, half-maximal inhibitory concentration: > 20000 nM
Compound 4: no number, only a limit; the forecaster's own chance of this, stated with the estimate: 70%; the middle value lies on the limit itself.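

Compound 1 and compound 4 both return only a limit in this assay and the step between them cannot be read: the limit of > 20000 nM in this assay, at which 3 of the 4 values shown sit.

The compounds shown leave open whether pyridin-2-yl in place of 4-bromophenyl on the shared core of compound 1 has any effect on the read-out, how large it is, and in which direction it runs.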